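Vinyl to prop-1-en-1-yl on compound 2

A few compounds are considered here, and "the series" means these few. Any claim that something is new, unique, unknown or untested is made for them only; others in the source may bear on it.

Of the compounds shown here, two have been measured so far. In a functional assay on Rec1 cells (Homo sapiens) for inhibition, read by luminescence and CellTiter-Glo, with a stated time of 72 h (a lower number here means a stronger inhibitor, a higher number a weaker inhibitor), compound 1 (`C/C=C/C(=O)N1CCCC(n2nc(-c3ccc(Oc4ccccc4)cc3)cc2C(=O)OCC)C1`) gives 5100 nM, and compound 2 (`C=CC(=O)N1CCCC(n2nc(-c3ccc(Oc4ccccc4)cc3)cc2C(=O)O)C1`) gives 50000 nM. Compound 2 therefore holds the higher of the two numbers, which makes it the weaker inhibitor of the pair, and the gap lies beyond the usual scatter.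

The unmeasured compound 3 (`C/C=C/C(=O)N1CCCC(n2nc(-c3ccc(Oc4ccccc4)cc3)cc2C(=O)O)C1`) differs from compound 2 in one place: prop-1-en-1-yl in place of vinyl on a carbonyl carbon. Prop-1-en-1-yl stands in place of vinyl on a carbonyl carbon whose other neighbours are: amide-type nitrogen in a ring.

Within the data shown here, no measured pair of compounds isolates this change, so the data give no direct size for it. The closest reference is compound 2 at 50000 nM, and no step beyond the scatter is expected from it in this assay. The estimated change is a 1.3-fold lower number from compound 2 to compound 3 (0.10 log units; within the scatter), which would stay within the scatter. For compound 3 the expected value is 40000 nM, with an estimated range from 15000 nM to 100000 nM.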

Compound 3, half-maximal inhibitory concentration: 31000 nM
The estimate for compound 3 lay 1.3-fold (0.11 log units) above the measured number; the measured number falls inside the stated range.
By their numbers in this assay, from the lowest: compound 1; then compounds 3 and 2 (each within the scatter of the next).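

In this assay, prop-1-en-1-yl in place of vinyl on a carbonyl carbon gives a 1.6-fold lower number from compound 2 to compound 3 (0.21 log units; within the scatter), so with hydrogen on the oxygen next to the carbonyl group, this assay does not separate the two groups. Compound 3 also provides a single-place comparison at that oxygen: hydrogen in place of ethyl gives a 6.1-fold higher number from compound 1 to compound 3 (0.78 log units; beyond the scatter), so among the steps shown, only this change at the oxygen moves the number beyond the scatter. Nothing available explains either step.

The compounds shown leave open whether vinyl and prop-1-en-1-yl would also read alike with ethyl on that oxygen, since the comparison between them exists only with hydrogen there. Also open, on these data alone, is how a longer chain than ethyl on that oxygen, or a dimethylamino group on the prop-1-en-1-yl, would read in this assay.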